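Chalcone ethers: removing the ring chloro from compound 1

The compounds below may be only part of what the source reports. "The series", "measured", "known", "first", "only" and "open" are said of these compounds alone.

Compound 1 `Cc1ccc(COc2ccc(C(=O)/C=C/c3ccc(Cl)cc3)cc2)cc1` carries a chloro on the cinnamoyl-side ring and a methyl on the benzyloxy ring. In a functional assay on HCT-116 cells (Homo sapiens) for inhibition, read by sulforhodamine B assay, with a stated time of 3 days (on this read-out lower numbers stand for stronger inhibition of growth and higher numbers for weaker inhibition of growth), compound 1 reaches only the limit of the assay, > 50000 nM, so no number stands for it. The second measured member, compound 2 `O=C(/C=C/c1ccccc1Cl)c1ccc(OCc2ccccc2)cc1`, differs in two places at once, with the chloro moved and the benzyloxy methyl absent; in this assay compound 2 gives 14900 nM. Going by the values given here, no single-point comparison between measured compounds exists here, so the pair shows only that one value is a limit and the other a modest number.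

Compound 3 `Cc1ccc(COc2ccc(C(=O)/C=C/c3ccccc3)cc2)cc1` is the unmeasured neighbour of compound 1. The change is hydrogen in place of chloro on an aromatic carbon, the same difference read one bond further out being 4-chlorophenyl to phenyl. Since compound 1 sits at the limit (the limit of > 50000 nM in this assay, at which 1 of the 2 values shown sits), the step cannot be measured downward from a number; the expectation is for no movement beyond the scatter, with a fair chance that compound 3 again returns only a limit. The expected step is an at least 1.2-fold lower number from compound 1 to compound 3 (0.09 log units; that floor lies within the scatter). Compound 3 is estimated at 40000 nM, with a range from 15000 nM to 100000 nM.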

Compound 3, concentration for 50% growth inhibition: > 50000 nM
Compound 3 was reported as a limit; the forecaster's own chance of this, stated with the estimate: 55%; middle value at least 1.2-fold (0.09 log units) from the limit.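

In this assay compound 3 gives > 50000 nM, which is a limit and not a number. With compound 1 also at a limit, no step can be read between compound 1 and compound 3: the limit of > 50000 nM in this assay, at which 2 of the 3 values shown sit.

The compounds shown leave open whether hydrogen in place of chloro on this aromatic carbon changes growth inhibition at all.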